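A few compounds are considered here, and "the series" means these few. Any claim that something is new, unique, unknown or untested is made for them only; others in the source may bear on it.

In a functional assay on DU-145 cells (Homo sapiens) for inhibition, read by trypan blue exclusion, with a stated time of 96 h (a lower number here means a stronger inhibitor of growth, a higher number a weaker inhibitor of growth), compound 1 (`Cc1cc(C)cc(/C=C(/SCc2ccc(F)cc2)C(=O)c2ccc(Br)cc2)c1`) gives 10000 nM and compound 2 (`Cc1ccc(S/C(=C/c2sccc2C)C(=O)c2ccc(Br)cc2)cc1`) gives 50000 nM while compound 3 (`Cc1ccsc1/C=C(/SCc1ccc(F)cc1)C(=O)c1ccc(Cl)cc1`) gives 50000 nM in the same test. Compound 3 therefore stands level with compound 2, the two sharing the highest number of the three, while compound 1 has a lower number, a gap beyond the scatter. Compound 4 (`Cc1ccsc1/C=C(/SCc1ccc(F)cc1)C(=O)c1ccc(Br)cc1`) has not yet been measured in this assay and differs from compound 3 in one place (bromo in place of chloro on an aromatic carbon), with bromo in place of chloro on an aromatic carbon. Within the data shown here, no measured pair shows this change on its own. The 4-bromophenyl group already occurs in compound 2 (50000 nM) and in compound 1 (10000 nM), so its presence points to no single level. No shift beyond the scatter is expected, and the estimated step is small (a 1.7-fold lower number from compound 3 to compound 4 (0.22 log units; within the scatter)). For compound 4 the expected value is 30000 nM with an estimated range (10000 nM to 70000 nM).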

Compound 4, concentration for 50% growth inhibition: 50000 nM
Compound 4: the middle estimate sits 1.7-fold (0.22 log units) below what was measured; measured number inside the range.
By their numbers in this assay, from the lowest: compound 1; then compounds 2, 3 and 4 (each within the scatter of the next).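

In this assay the exchange of halogen on the aromatic carbon, para to a large group, gives no measurable difference (no change at the digits printed from compound 3 to compound 4 (within the scatter)), so with these partners 4-chlorophenyl and 4-bromophenyl cannot be told apart. Among these compounds, with 4-bromophenyl held constant, the sulfur substituent also makes no measurable difference (no change at the digits printed from compound 2 to compound 4 (within the scatter)), while the group on the double-bonded chain carbon does (a 5.0-fold higher number from compound 1 to compound 4 (0.70 log units; beyond the scatter)), making that the only one of these three changes to go beyond the scatter. No measurement here accounts for any of these outcomes.

On these data alone, it remains open whether a methoxy group or a nitrile in place of the halogen would shift the number. As far as these compounds go, it is also open whether chloro and bromo would still match alongside the 3,5-dimethylphenyl group of compound 1.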